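The compounds below may be only part of what the source reports. "The series", "measured", "known", "first", "only" and "open" are said of these compounds alone.

Measured compounds in a functional assay on EKVX cells (Homo sapiens) for inhibition, read by sulforhodamine B assay, with a stated time of 48 h; on this read-out lower numbers stand for higher toxicity in this test and higher numbers for lower toxicity in this test:
compound 1, `COc1cc(CNc2nc3cc(N)cc(N)c3nc2-c2ccccc2)cc(OC)c1OC`, gives 27500 nM.
Compound 2, `CCOC(=O)[C@H](CCC(=O)O)NC(=O)c1ccc(Oc2nc3cc(N)cc(N)c3nc2-c2ccccc2)cc1`, returns only a limit, < 100000 nM.
Compound 3, `COc1ccc(CNc2nc3cc(N)cc(N)c3nc2-c2ccccc2)cc1OC`, also returns only a limit, < 100000 nM.

Compound 3 therefore stands without a number in this assay; its value is a limit, and one further value in the set is a limit as well. Compound 1 carries the only number shown. For the measured compounds named here, the one step that touches compound 3 is a step that the limit leaves unreadable from compound 1 to compound 3, which the limit leaves unreadable, so the size of putting hydrogen in place of methoxy there is not known. the limit of < 100000 nM in this assay, at which 2 of the 3 values shown sit, shows how much of the set sits at that limit.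

Compound 4, `COc1ccc(CNc2nc3cc(N)cc(N)c3nc2-c2ccccc2)cc1`, is to be measured in this assay. It differs from compound 3 by hydrogen in place of methoxy on an aromatic carbon. Going by the values given here, this is the same kind of change as the one from compound 1 to compound 3, and that one gave no readable size. Among the compounds with values here, no measured step bears readably on the change to compound 4, so the expected size in this assay cannot be drawn from a step; the expectation rests on the limit for compound 3 and the number for compound 1.

Compound 4 is expected to give about 50000 nM, within 15000 nM to 100000 nM. The step is estimated as a step that the limit leaves unreadable from compound 3 to compound 4, with a fair chance that this assay again reports only a limit.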

Compound 4, concentration lethal to 50% of the cells: 53700 nM
The estimate for compound 4 lay 1.1-fold (0.03 log units) below the measured number; low and high end bracket the measured number.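

Compound 3 carries only a limit, < 100000 nM, in this assay, so no new step can be read from compound 3 to compound 4. The compounds shown leave open what size, if any, putting hydrogen in place of methoxy on an aromatic carbon has in this assay, for compound 1 to compound 3 and for compound 3 to compound 4 alike.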